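The source may hold more compounds than are shown below. What is called first, only, known or untested is meant among the compounds shown, and "the series" means these compounds.

Compound 3 `Cc1noc(NS(=O)(=O)c2cccc3ccccc23)c1C` gives 20000 nM in an assay on VSM-A10 cells for antagonist activity at Endothelin-1 receptor (Rattus norvegicus); on this read-out higher numbers stand for weaker inhibition and lower numbers for stronger inhibition. Among the three measured compounds it stands second highest. Compound 1 `Cc1noc(NS(=O)(=O)c2cccc3c(Cl)cccc23)c1C` gives 24000 nM, close to it, whereas compound 2 `Cc1noc(NS(=O)(=O)c2cccc3c(NCc4ccccc4)cccc23)c1C` gives 590 nM, far lower. Compound 4 `Cc1noc(NS(=O)(=O)c2cccc3c(C(C)(C)O)cccc23)c1C` changes one place on the shared core: 1-hydroxy-1-methylethyl in place of hydrogen on an aromatic carbon. Going by the values given here, two measured steps touch the same place. There was a 1.2-fold lower number from compound 1 to compound 3 (0.08 log units; within the scatter), so a chloro there changed little, while there was a 34-fold higher number from compound 2 to compound 3 (1.53 log units; beyond the scatter), so a benzylamino there made a large difference. The entering group is neither, and a moderate lowering in this assay is expected, a 2.5-fold lower number from compound 3 to compound 4 (0.40 log units; beyond the scatter). Compound 4 is therefore estimated at 8000 nM, with a range from 2500 nM to 25000 nM.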

Compound 4, half-maximal inhibitory concentration: 2890 nM
Compound 4: the middle estimate sits 2.8-fold (0.44 log units) above what was measured; the range from low to high includes it.
By their numbers in this assay, from the lowest: compound 2; then compound 4; then compounds 3 and 1 (each within the scatter of the next).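

In this assay there was a 6.9-fold lower number from compound 3 to compound 4 (0.84 log units; beyond the scatter), and also an 8.3-fold lower number from compound 1 to compound 4 (0.92 log units; beyond the scatter), so a group with no ring can lower the number at this position, which the chloro did not do. Compound 2 keeps the lowest number, with a 4.9-fold higher number from compound 2 to compound 4 (0.69 log units; beyond the scatter), so 1-hydroxy-1-methylethyl reaches only part of the way to benzylamino. No measurement here explains these differences. Still open, going by these compounds, is whether the oxygen of the new group matters, which a tert-butyl group would test. A plain amino group would show whether the nitrogen of benzylamino suffices without its ring.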